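From Compound 3 to Compound 4: A New Nitrogen Substituent

The source may report more compounds than this note shows. Statements on the series, on what has been measured and on what is new or still open speak of the compounds shown alone.

In a functional assay on G-361 cells (Homo sapiens) for cytotoxicity, read by MTT assay, with a stated time of 3 days (a higher number here means a weaker inhibitor, a lower number a stronger inhibitor), compound 1 `N#Cc1c(Nc2ccccc2)nc(SCc2nc3ccccc3[nH]2)nc1-c1ccccc1` gives 2.4 nM, compound 2 `CNc1nc(SCc2nc3ccccc3[nH]2)nc(-c2ccccc2)c1C#N` gives 12.5 nM and compound 3 `N#Cc1c(NNC(N)=S)nc(SCc2nc3ccccc3[nH]2)nc1-c1ccccc1` gives 3.96 nM. Compound 3 therefore lies within the scatter of compound 1, and its number is lower than that of compound 2. Compound 4 `N#Cc1c(NC(N)=O)nc(SCc2nc3ccccc3[nH]2)nc1-c1ccccc1` differs from compound 3 as follows: a group of 3 heavy atoms (1 carbon, 1 nitrogen, 1 oxygen; no ring) in place of a group of 4 heavy atoms (1 carbon, 2 nitrogen, 1 sulfur; no ring), on a nitrogen on an aromatic ring. Three measured steps changed the group on this same nitrogen. The step of a 1.7-fold higher number from compound 1 to compound 3 (0.22 log units; within the scatter) stayed within the scatter, and a 3.2-fold lower number from compound 2 to compound 3 (0.50 log units; beyond the scatter) was modest. The largest, a 5.2-fold higher number from compound 1 to compound 2 (0.72 log units; beyond the scatter), was also modest, so only a small shift seems likely in this assay. The expected change is a 1.3-fold higher number from compound 3 to compound 4 (0.10 log units; within the scatter), which would not exceed the scatter. For compound 4 the estimated value is 5 nM, with an expected range of 2 nM to 12 nM.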

Compound 4, half-maximal inhibitory concentration: 2.55 nM
For compound 4 the middle estimate is 2.0-fold (0.29 log units) above the measured one; measured number inside the range.
By their numbers in this assay, from the lowest: compounds 1, 4 and 3 (each within the scatter of the next); then compound 2.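

In this assay a ring on this nitrogen is not needed to match phenyl: carbamoyl, which has no ring, shows a 1.1-fold higher number from compound 1 to compound 4 (0.03 log units; within the scatter) and stays within the scatter. Exchanging the group of 4 heavy atoms for carbamoyl also stays within the scatter, at a 1.6-fold lower number from compound 3 to compound 4 (0.19 log units; within the scatter) for this change. Only methyl stands apart from carbamoyl, with a 4.9-fold lower number from compound 2 to compound 4 (0.69 log units; beyond the scatter) as a modest step beyond the scatter.

As far as these compounds go, whether a carboxylic acid or a longer chain on this nitrogen would fall with carbamoyl or with methyl remains open. No measurement available here explains these steps.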